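Working notes: from compound 2 to compound 3

The source may hold more compounds than are shown below. What is called first, only, known or untested is meant among the compounds shown, and "the series" means these compounds.

- compound 1 `C[C@H]1CC[C@@H]2[C@@H](OC(=O)[C@]23CC(c2ccc(N(C)C)cc2)=NO3)[C@]2(C)C(=O)C=C[C@@]12O` gives 4500 nM 
- compound 2 `Cc1cccc(C2=NO[C@]3(C2)C(=O)O[C@@H]2[C@H]3CC[C@H](C)[C@]3(O)C=CC(=O)[C@@]23C)c1` gives 28000 nM 

In a functional assay on DU-145 cells (Homo sapiens) for cytotoxicity, read by sulforhodamine B assay, with a stated time of 48 h (on this read-out lower numbers stand for stronger inhibition and higher numbers for weaker inhibition), compound 2 has the higher of the two numbers (28000 nM). The next case is compound 3 `C[C@H]1CC[C@@H]2[C@@H](OC(=O)[C@]23CC(c2ccc(C#N)cc2)=NO3)[C@]2(C)C(=O)C=C[C@@]12O`, with 4-cyanophenyl in place of 3-methylphenyl on a carbon with a double bond to nitrogen. For the measured compounds named here, one measured step bears on this place: with 3-methylphenyl in place of 4-(dimethylamino)phenyl, the series shows a modest change beyond the scatter (a 6.2-fold higher number from compound 1 to compound 2 (0.79 log units; beyond the scatter)). Going by the values given here, no measured compound carries 4-cyanophenyl, so that single step gives only a rough guide to size. For compound 3 the expected change in this assay is toward a lower number and smaller than that measured step, estimated as a 2.3-fold lower number from compound 2 to compound 3 (0.37 log units; beyond the scatter) here. The estimated value for compound 3 is 12000 nM (expected range 4000 nM to 35000 nM).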

Compound 3, half-maximal inhibitory concentration: 26000 nM
Estimate against measurement, compound 3: 2.2-fold (0.34 log units) below; the range from low to high includes it.
By their numbers in this assay, from the lowest: compound 1; then compounds 3 and 2 (each within the scatter of the next).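

Working on the series in this assay, 4-cyanophenyl and 3-methylphenyl on this carbon read alike, with a 1.1-fold lower number from compound 2 to compound 3 (0.03 log units; within the scatter). Exchanging dimethylamino for cyano on the aromatic carbon gives a 5.8-fold higher number from compound 1 to compound 3 (0.76 log units; beyond the scatter), so compound 1 now stands apart from two different aryl groups rather than one and is the most potent of the three compounds. Nothing on hand accounts for this difference.

The compounds shown leave open whether the lower number of compound 1 belongs to dimethylamino specifically or would also appear with a primary amine or a morpholine on the phenyl ring. They also leave open how a carboxylic acid on that ring, or a longer chain on the amine nitrogen, would read in this assay.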